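The compounds below may be only part of what the source reports. "The series", "measured", "known", "first", "only" and "open" are said of these compounds alone.

Working notes on the series. Compound 1 `Cc1cccc(NC(=O)Nc2cc(Oc3ccc4nc(NC(=O)C5CC5)sc4c3)ccc2F)c1` and compound 2 `O=C(Nc1cccc(Br)c1)Nc1cc(Oc2ccc3nc(NC(=O)C4CC4)sc3c2)ccc1F` share one core and differ in one place only. In a functional assay on HT-29 cells (Homo sapiens) for inhibition, read by luminescence and CellTiter-Glo, with a stated time of 12 h (on this read-out lower numbers stand for an effect already at smaller amounts and higher numbers for an effect only at larger amounts of compound), compound 1 gives 580 nM, and in the same read-out compound 2 gives 440 nM. For the measured compounds named here, the single measured step, a 1.3-fold lower number from compound 1 to compound 2 (0.12 log units; within the scatter), is the whole record so far. Compound 2 holds the lower of the two numbers, with compound 1 its nearest neighbour, but the gap between them is within the scatter, so no order is read between them.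

Compound 3 `COc1cccc(NC(=O)Nc2cc(Oc3ccc4nc(NC(=O)C5CC5)sc4c3)ccc2F)c1` is the next point. The change from compound 2 to compound 3 is methoxy in place of bromo on an aromatic carbon. The measured step bears on it only loosely: it shows that exchanging one substituent for another at this place moved the number within the scatter. A third substituent at the same place is therefore expected to give a step of a 1.3-fold higher number from compound 2 to compound 3 (0.10 log units; within the scatter), nothing beyond the scatter. Compound 3 is expected at 550 nM in this assay, with a range from 250 nM to 1300 nM.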

Compound 3, half-maximal effective concentration: 1370 nM
Estimate against measurement, compound 3: 2.5-fold (0.40 log units) below; measured number outside the range, above it.
By their numbers in this assay, from the lowest: compounds 2 and 1 (each within the scatter of the next); then compound 3.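

In this assay this place proves sensitive to its substituent, which the earlier pair could not show: methoxy in place of bromo gives a step beyond the scatter (a 3.1-fold higher number from compound 2 to compound 3 (0.49 log units; beyond the scatter)), and methoxy in place of methyl gives another (a 2.4-fold higher number from compound 1 to compound 3 (0.37 log units; beyond the scatter)). Of the three groups, methoxy alone stands apart, since bromo and methyl remain within the scatter of each other. Nothing available bears on why the number is higher with methoxy.

Going by these compounds, whether this higher number is particular to methoxy remains open, and an amine, a carboxylic acid or a longer chain such as ethoxy at the same place would test that. Also open, on these data alone, is how methoxy behaves on another carbon of this ring, as all three groups shown sit meta to a large group.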